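Cytotoxicity notes on a shared-core series

This account rests on a few compounds, and the source may have more. Where it says the series, first, only, none or still open, it means among the compounds named here.

Compound 2 `Fc1cccc(F)c1Cc1cnc(Nc2ccc(-c3cccnc3)c(Cl)c2)o1` stands at the lowest of the two numbers in an ADME assay on MT2 cells (Homo sapiens) for cytotoxicity, read by MTT assay (a higher number here means that more compound is tolerated, a lower number that less compound is tolerated), where compound 2 gives 8900 nM; compound 1 `Fc1cccc(F)c1Cc1cnc(Nc2ccc(-c3ccncc3)c(Cl)c2)o1` gives 9300 nM, and a 1.0-fold lower number from compound 1 to compound 2 (0.02 log units; within the scatter). For the measured compounds named here, compound 3 `[O-][n+]1ccc(OCc2ccc(Nc3ncc(Cc4c(F)cccc4F)o3)cc2Cl)cc1` differs from compound 2 by a group of 9 heavy atoms (6 carbon, 1 nitrogen, 2 oxygen; one six-membered aromatic ring with 1 hetero atom) in place of a group of 6 heavy atoms (5 carbon, 1 nitrogen; one six-membered aromatic ring with 1 hetero atom), on an aromatic carbon The only measured step exchanged one six-membered aromatic ring with one hetero atom for another at the same aromatic carbon and stayed within the scatter, so no step beyond the scatter is expected in this assay. The estimate for compound 3 is 9000 nM, with a range from 4000 nM to 20000 nM. The step expected is a 1.0-fold higher number from compound 2 to compound 3 (0.00 log units; within the scatter).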

Compound 3, half-maximal cytotoxic concentration: 1700 nM
Compound 3: the middle estimate sits 5.3-fold (0.72 log units) above what was measured; measured number below the stated range.
By their numbers in this assay, from the lowest: compound 3; then compounds 2 and 1 (each within the scatter of the next).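

This position is not indifferent to every six-membered aromatic ring group in this assay: the larger oxygen-bearing group gives a 5.2-fold lower number from compound 2 to compound 3 (0.72 log units; beyond the scatter) and a 5.5-fold lower number from compound 1 to compound 3 (0.74 log units; beyond the scatter), whereas the exchange of pyridin-4-yl for pyridin-3-yl gave no step beyond the scatter. Less compound is therefore tolerated with this change on the aromatic carbon ortho to the chloro group. Nothing available explains the drop.

Which part of the entering group goes with the step remains open. Also open, on these data alone, is whether a methoxy group or an amine on this carbon would stay with compound 2 or fall with compound 3.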